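The source may report more compounds than this note shows. Statements on the series, on what has been measured and on what is new or still open speak of the compounds shown alone.

Measured so far:
Compound 1 `COc1cc(/C=C/c2ccc(OC)cc2O)cc(OC)c1` gives 800 nM in a functional assay on MGC-803 cells (Homo sapiens) for antiproliferative activity, read by MTT assay; on this read-out lower numbers stand for stronger inhibition and higher numbers for weaker inhibition.
Compound 2 `COc1cc(/C=C/c2cc([N+](=O)[O-])ccc2O)cc(OC)c1OC` gives 14700 nM in this assay.

Of these two numbers, compound 2 carries the higher one, so it is the weaker inhibitor of the pair; compound 1 lies well apart from it, beyond the usual scatter. Compound 3 `COc1cc(/C=C/c2cc([N+](=O)[O-])ccc2O)cc(OC)c1` is compound 2 with a single change: hydrogen in place of methoxy on an aromatic carbon. Among the measured compounds shown here, no measured pair shows this exact change, so its effect is unknown from these data. The expected step is a 1.2-fold lower number from compound 2 to compound 3 (0.09 log units; within the scatter), small and in no certain direction, probably within the scatter. Compound 3 is therefore estimated at 12000 nM, with a range from 3000 nM to 50000 nM.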

Compound 3, half-maximal inhibitory concentration: 10600 nM
Compound 3: middle estimate off by 1.1-fold (0.05 log units), on the high side, within the range that was stated.
By their numbers in this assay, from the lowest: compound 1; then compounds 3 and 2 (each within the scatter of the next).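

At this place on the ring, ortho to two methoxy groups and para to a large group, hydrogen in place of methoxy gives a 1.4-fold lower number from compound 2 to compound 3 (0.14 log units; within the scatter) in this assay. On this pair, then, the methoxy can go without a change that stands out from the usual scatter. Nothing measured here gives a reason for this result. On these data alone, whether an amine, a fluorine atom or a longer chain such as propoxy at this place would shift the number stays open. So does whether the same swap would behave alike on a core without the nitro group.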